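Lengthening the chain between oxygen and phenyl

The source may hold more compounds than are shown below. What is called first, only, known or untested is meant among the compounds shown, and "the series" means these compounds.

Compound 1 `O=c1[nH]/c(=N\OCCCc2ccccc2)ccn1[C@@H]1O[C@H](COP(=O)(O)OP(=O)(O)OP(=O)(O)O)[C@@H](O)[C@H]1O`: 640 nM
Compound 2 `CCO/N=c1/ccn([C@@H]2O[C@H](COP(=O)(O)OP(=O)(O)OP(=O)(O)O)[C@@H](O)[C@H]2O)c(=O)[nH]1`: 817 nM
Compound 3 `O=c1[nH]/c(=N\OCc2ccccc2)ccn1[C@@H]1O[C@H](COP(=O)(O)OP(=O)(O)OP(=O)(O)O)[C@@H](O)[C@H]1O`: 620 nM

These three compounds share one core and differ only in the group on the oxygen. In an in vitro functional assay on 1321-N1 cells for agonist activity at P2Y purinoceptor 2 (Homo sapiens), read by scintillation proximity assay and inositol phosphate accumulation, with a stated time of 30 min (on this read-out higher numbers stand for an effect only at larger amounts of compound and lower numbers for an effect already at smaller amounts), compound 3 gives 620 nM; this is the lowest of the three numbers, but the gaps to compound 1 and compound 2 are both within the scatter, so no order among them can be claimed.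

Compound 4 `O=c1[nH]/c(=N\OCCc2ccccc2)ccn1[C@@H]1O[C@H](COP(=O)(O)OP(=O)(O)OP(=O)(O)O)[C@@H](O)[C@H]1O` has not yet been measured. Its change from compound 3 is benzyl in place of phenyl on a saturated chain carbon bound to an oxygen. The measured steps that bear on it are a 1.0-fold lower number from compound 1 to compound 3 (0.01 log units; within the scatter), a 1.3-fold lower number from compound 2 to compound 3 (0.12 log units; within the scatter) and a 1.3-fold higher number from compound 1 to compound 2 (0.11 log units; within the scatter): every change of the chain on that oxygen, shorter or longer, stayed within the scatter. Compound 4 lies in chain length between compound 3 and compound 1, both of which gave nearly the same number, so no step beyond the scatter is expected in this assay.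

For compound 4 the estimate is 650 nM, with a range from 300 nM to 1400 nM. The expected step from compound 3 is therefore a 1.0-fold higher number from compound 3 to compound 4 (0.02 log units; within the scatter).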

Compound 4, half-maximal effective concentration: 1200 nM
Estimate against measurement, compound 4: 1.8-fold (0.27 log units) below; the range from low to high includes it.
By their numbers in this assay, from the lowest: compounds 3, 1, 2 and 4 (each within the scatter of the next).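

In this assay, phenethyl on this oxygen adds a further chain length, and all three of its steps stay within the scatter: a 1.9-fold higher number from compound 3 to compound 4 (0.29 log units; within the scatter), a 1.9-fold higher number from compound 1 to compound 4 (0.27 log units; within the scatter) and a 1.5-fold higher number from compound 2 to compound 4 (0.17 log units; within the scatter). The first two are the largest steps seen on this chain so far, yet the four compounds, from the short ethyl chain to the longest chain with phenyl at its end, still cannot be placed in any order. Nothing further is available that could tell what lies behind these small differences.

From the compounds shown here alone, it remains open whether a much longer chain would give a step beyond the scatter. The same holds for an amine or a carboxylic acid at the end of the chain, or for a chlorine on the phenyl ring.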